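Chain length and acid ceramidase inhibition: toward compound 4

The source may report more compounds than this note shows. Statements on the series, on what has been measured and on what is new or still open speak of the compounds shown alone.

The series is followed in an assay on HEK293 cells for inhibition of acid ceramidase (Rattus norvegicus), read by LC-MS, with a stated time of 30 min; a higher number here means a weaker inhibitor, a lower number a stronger inhibitor. Of the compounds shown here, three carry numbers so far. Compound 2 `CCCCNC(=O)n1ccc(=O)[nH]c1=O` gives 8500 nM. Compound 3 `CCCCCNC(=O)n1ccc(=O)[nH]c1=O` gives 2100 nM, and compound 1 `CCCCCCNC(=O)n1cc(N2CCN(C)CC2)c(=O)[nH]c1=O` gives 1400 nM. Compound 3 therefore stands second highest of the three numbers; its nearest neighbour is compound 1, within the scatter, and its furthest is compound 2, beyond it. For the measured compounds named here, the one step in which two measured compounds differ in a single place is a 4.0-fold lower number from compound 2 to compound 3 (0.61 log units; beyond the scatter).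

Compound 4 `CCCCCCCNC(=O)n1ccc(=O)[nH]c1=O` has not yet been measured. It differs from compound 3 by ethyl in place of hydrogen on a saturated chain carbon, five bonds along the chain from an amide-type nitrogen. Going by the values given here, the only measured step that bears on this change is a 4.0-fold lower number from compound 2 to compound 3 (0.61 log units; beyond the scatter), which runs in the same sense, lengthening the chain carried by the amide-type nitrogen. A further extension of that chain is expected to continue toward lower numbers in this assay, although the pair compound 1 and compound 3 sits within the scatter and so gives no guide of its own. The expected step is a 3.8-fold lower number from compound 3 to compound 4 (0.58 log units; beyond the scatter). Compound 4 is thus estimated at 550 nM, with a range from 200 nM to 1500 nM.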

Compound 4, half-maximal inhibitory concentration: 325 nM
For compound 4 the middle estimate is 1.7-fold (0.23 log units) above the measured one; the measured number falls inside the stated range.
By their numbers in this assay, from the lowest: compound 4; then compounds 1 and 3 (each within the scatter of the next); then compound 2.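

In this assay, for the compounds shown here, ethyl in place of hydrogen on a saturated chain carbon, five bonds along the chain from an amide-type nitrogen, gives a 6.5-fold lower number from compound 3 to compound 4 (0.81 log units; beyond the scatter), so the move toward lower numbers with a longer chain does not end with the single step read before. Over the whole run, lengthening the chain gives a 26-fold lower number from compound 2 to compound 4 (1.42 log units; beyond the scatter), the one large step in the series, and no compound with the shared core and no further group goes against this direction. Nothing measured alongside these numbers bears on why the number falls as the chain grows.

Still open, going by these compounds, is whether a longer chain than that of compound 4 keeps lowering the number or reverses the trend, and how a chain ending in an amine or a carboxylic acid would read at this position. Compound 1 differs from compound 4 in more than one place, so the contribution of its added ring group cannot be read from the compounds shown.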